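The compounds below may be only part of what the source reports. "The series", "measured", "known", "first", "only" and "open" are said of these compounds alone.

Of the compounds shown here, three from one series have been tested in an assay on cells for agonist activity at Bombesin receptor subtype-3 (Homo sapiens), read by HTRF and inositol phosphate accumulation, with a stated time of 1 h; on this read-out higher numbers stand for an effect only at larger amounts of compound and lower numbers for an effect already at smaller amounts. Compound 1 `COC(=O)c1c(F)cccc1-c1ccc(CCc2ncc(CC(C)(C)C)n2CCOc2cccc(O)c2)cc1` gives 13 nM. Compound 2 `COC(=O)c1c(F)cccc1-c1ccc(CCc2ncc(CC(C)(C)C)n2CCNS(C)(=O)=O)cc1` gives 11 nM. Compound 3 `CC(C)(C)Cc1cnc(CCc2ccc(-c3cccc(F)c3C(=O)O)cc2)n1CCOc1cccc(O)c1` gives 0.9 nM, the lowest number of the three.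

Compound 2 differs from compound 1 only by methanesulfonamido in place of 3-hydroxyphenoxy on a saturated chain carbon, two bonds along the chain from an aromatic nitrogen, and this change gave a 1.2-fold lower number from compound 1 to compound 2 (0.07 log units; within the scatter). Compound 3 differs from compound 1 only by hydrogen in place of methyl on an oxygen next to a carbonyl group, and this change gave a 14-fold lower number from compound 1 to compound 3 (1.16 log units; beyond the scatter).

Compound 4 `CC(C)(C)Cc1cnc(CCc2ccc(-c3cccc(F)c3C(=O)O)cc2)n1CCNS(C)(=O)=O` has not yet been measured in this assay. It differs from compound 3 by methanesulfonamido in place of 3-hydroxyphenoxy on a saturated chain carbon, two bonds along the chain from an aromatic nitrogen. This is the same change that separates compound 1 from compound 2, made on a different core: the core of compound 3 differs from that of compound 1 by hydrogen in place of methyl on an oxygen next to a carbonyl group, and the place of the change is the same in both pairs.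

Because the earlier instance of this change gave a 1.2-fold lower number from compound 1 to compound 2 (0.07 log units; within the scatter), a change lying within the scatter, compound 4 is expected to stay close to compound 3. The step from compound 3 to compound 4 is expected to be a 1.1-fold lower number from compound 3 to compound 4 (0.05 log units; within the scatter). For compound 4 the estimate in this assay is 0.8 nM, with a plausible range from 0.4 nM to 1.8 nM, resting on the value of compound 3 and on the step from compound 1 to compound 2.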

Compound 4, half-maximal effective concentration: 2 nM
For compound 4 the middle estimate is 2.5-fold (0.40 log units) below the measured one, outside the stated range (above it).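

In this assay, methanesulfonamido in place of 3-hydroxyphenoxy gave a 2.2-fold higher number from compound 3 to compound 4 (0.35 log units; beyond the scatter), a step beyond the scatter, whereas the same change on the core of compound 1 stayed within it, yet the two instances cannot be told apart: the same change on two cores in this assay, a 1.2-fold lower number (0.07 log units; within the scatter) from compound 1 to compound 2 and a 2.2-fold higher number (0.35 log units; beyond the scatter) from compound 3 to compound 4, 2.6-fold (0.42 log units) apart, within the scatter of two such steps

Read the other way round, the square of four compounds gives the same answer, with hydrogen in place of methyl on an oxygen next to a carbonyl group giving a 5.5-fold lower number from compound 2 to compound 4 (0.74 log units; beyond the scatter), again a lower number as on the 3-hydroxyphenoxy side: the same change on two cores in this assay, a 14-fold lower number (1.16 log units; beyond the scatter) from compound 1 to compound 3 and a 5.5-fold lower number (0.74 log units; beyond the scatter) from compound 2 to compound 4, 2.6-fold (0.42 log units) apart, within the scatter of two such steps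

The change therefore carried from one core to the other within the scatter of two such steps, but this rests on a single pair of cores and shows neither that the two steps are truly equal nor that the same would hold on any further core.

The compounds shown leave open how other groups would read in the same place, such as an acetamido group, a primary amine or a longer chain carrying the methanesulfonamido group. They also leave open whether a primary amide in place of the carboxylic acid would keep the lower numbers seen with the acid.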